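Swapping a hydroxyalkyl tail for a cyclopentyl on a diyne nucleoside

The source may report more compounds than this note shows. Statements on the series, on what has been measured and on what is new or still open speak of the compounds shown alone.

Measured so far:
- Compound 1, `Nc1cccc(C#CC#Cc2cn([C@H]3C[C@H](O)[C@@H](CO)O3)c(=O)[nH]c2=O)c1`. In an ADME assay on HEL cells (Homo sapiens) for cytotoxicity, read by microscopy (on this read-out lower numbers stand for higher toxicity in this test and higher numbers for lower toxicity in this test), compound 1 gives only a limit, > 100000 nM.
- Compound 2, `CC(O)CC#CC#Cc1cn([C@H]2C[C@H](O)[C@@H](CO)O2)c(=O)[nH]c1=O`. In this assay compound 2 likewise gives only a limit, > 100000 nM.

Both measured compounds share one core and differ only in the tail on a triple-bonded carbon. The step that the two limits leave unreadable from compound 1 to compound 2 cannot be sized, since each value is a limit rather than a number. Compound 2 therefore stands at the limit of > 100000 nM in this assay, at which 2 of the 2 values shown sit, with no number of its own.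

Compound 3, `O=c1[nH]c(=O)n([C@H]2C[C@H](O)[C@@H](CO)O2)cc1C#CC#CCC1CCCC1`, has not been measured. It differs from compound 2 by cyclopentyl in place of 1-hydroxyethyl on a saturated chain carbon bound to a triple-bonded carbon. Within the data shown here, no measured step bears directly on this change: the one step known is unreadable, and the only evidence is the limit of > 100000 nM in this assay, at which 2 of the 2 values shown sit, at which both measured values sit. With no readable step and no sign of toxicity in either neighbour, no movement beyond the scatter is expected from compound 2 to compound 3, so the estimated step is a number no higher from compound 2 to compound 3 (the limit leaves the size open). Compound 3 is estimated at 100000 nM, within 30000 nM to 300000 nM, most probably again reported only as a limit.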

Compound 3, minimum cytotoxic concentration: > 100000 nM
Compound 3: only a limit was reported; the forecaster's own chance of this, stated with the estimate: 70%; the middle value lies on the limit itself.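

In this assay compound 3 gives only a limit, > 100000 nM. Its steps from compound 1 and from compound 2 therefore cannot be read, so no new step emerges: the limit of > 100000 nM in this assay, at which 3 of the 3 values shown sit.

The compounds shown leave open how the three tails compare, and at what concentration, if any, toxicity to these cells would appear.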